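The compounds below may be only part of what the source reports. "The series", "measured", "known", "first", "only" and "open" are said of these compounds alone.

For the measured compounds named here, in a functional assay on KB cells (Homo sapiens) for cytotoxicity (a lower number here means that less compound is needed, a higher number that more compound is needed for the effect), compound 1 (`c1ccc(COc2cc(-c3ccccc3)nc3ccccc23)cc1`) gives 1.6 ug/mL, the higher of the two numbers so far, while compound 2 (`Oc1ccc2c(O)cc(-c3ccccc3)nc2c1`) gives 0.55 ug/mL, a gap beyond the scatter. These two compounds differ in more than one place, so their gap does not isolate any single change. Compound 3 (`CCCOc1cc(-c2ccccc2)nc2ccccc12`) keeps the core of compound 1 and has ethyl in place of phenyl on a saturated chain carbon bound to an oxygen on an aromatic ring, which turns benzyloxy into propoxy: ethyl in place of phenyl on a saturated chain carbon bound to an oxygen on an aromatic ring. Going by the values given here, no measured single-place step is available as a guide, so the expectation in this assay is weakly grounded. The expected change is a 1.3-fold higher number from compound 1 to compound 3 (0.10 log units; within the scatter), which would be no step beyond the scatter. For compound 3 the estimated value is 2 ug/mL, with an expected range of 0.7 ug/mL to 6 ug/mL.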

Compound 3, half-maximal effective concentration: 4.5 ug/mL
Estimate against measurement, compound 3: 2.3-fold (0.35 log units) below; the measured number falls inside the stated range.
By their numbers in this assay, from the lowest: compound 2; then compound 1; then compound 3.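

At the saturated chain carbon bound to an oxygen on an aromatic ring, this assay now has its first single-place reading: ethyl in place of phenyl, which turns benzyloxy into propoxy, gives a 2.8-fold higher number from compound 1 to compound 3 (0.45 log units; beyond the scatter), a modest step. This position is therefore not indifferent to the group it carries, and in this one pair the phenyl form needs less compound than the ethyl form. No measured property bears on this step, so the pair describes the change without explaining it.

One pair cannot separate the loss of the aromatic ring from the other differences between phenyl and ethyl, and a cyclohexyl group at the same place would bear directly on that. Also open, as far as these compounds go, is where a longer chain such as hexyl, or an amine at the chain end, would fall relative to compound 1 and compound 3.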